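A few compounds are considered here, and "the series" means these few. Any claim that something is new, unique, unknown or untested is made for them only; others in the source may bear on it.

Three compounds were measured in an in vitro functional assay on 1321-N1 cells for agonist activity at P2Y purinoceptor 6 (Homo sapiens), read by scintillation proximity assay and inositol phosphate accumulation, with a stated time of 30 min; on this read-out lower numbers stand for an effect already at smaller amounts and higher numbers for an effect only at larger amounts of compound:

Compound 1 `O=c1[nH]/c(=N\OCc2ccccc2)ccn1[C@@H]1O[C@H](COP(=O)(O)OP(=O)(O)OP(=O)(O)OP(=O)(O)O[C@H]2O[C@H](CO)[C@@H](O)[C@H](F)[C@H]2O)[C@@H](O)[C@H]1O` gives 7510 nM.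
Compound 2 `CO/N=c1/ccn([C@@H]2O[C@H](COP(=O)(O)OP(=O)(O)OP(=O)(O)OP(=O)(O)O[C@H]3O[C@H](CO)[C@@H](O)[C@H](F)[C@H]3O)[C@@H](O)[C@H]2O)c(=O)[nH]1` gives 1440 nM.
Compound 3 `O=c1[nH]/c(=N\OCCCc2ccccc2)ccn1[C@@H]1O[C@H](COP(=O)(O)OP(=O)(O)OP(=O)(O)O)[C@@H](O)[C@H]1O` gives 740 nM.

Compound 3 has the lowest number of the three in this assay; compound 2 lies within the scatter of it, and compound 1 lies beyond it. Compound 4 `O=c1[nH]/c(=N\OCc2ccccc2)ccn1[C@@H]1O[C@H](COP(=O)(O)OP(=O)(O)OP(=O)(O)O)[C@@H](O)[C@H]1O` differs from compound 3 in one place: phenyl in place of phenethyl on a saturated chain carbon bound to an oxygen. Within the data shown here, no measured pair shows the same change. Among the measured compounds shown here, the only measured step, a 5.2-fold lower number from compound 1 to compound 2 (0.72 log units; beyond the scatter), concerns the tetraphosphate pair and removes the phenyl ring entirely, so it bears on the step to compound 4 only loosely, as a sign that this region tolerates change of modest size. For the measured compounds named here, with no direct precedent, the step from compound 3 to compound 4 is expected to be a 1.5-fold higher number from compound 3 to compound 4 (0.17 log units; within the scatter) in this assay, most likely within the scatter. Compound 4 is therefore estimated at 1100 nM, with a range from 350 nM to 3500 nM.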

Compound 4, half-maximal effective concentration: 230 nM
For compound 4 the middle estimate is 4.8-fold (0.68 log units) above the measured one; the measured number lies below the stated range.
By their numbers in this assay, from the lowest: compound 4; then compounds 3 and 2 (each within the scatter of the next); then compound 1.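

In this assay, shortening 3-phenylpropoxy to benzyloxy while keeping the phenyl ring gives a 3.2-fold lower number from compound 3 to compound 4 (0.51 log units; beyond the scatter). This shows that the read-out at this position responds to chain length alone, which the earlier step could not show: a 5.2-fold lower number from compound 1 to compound 2 (0.72 log units; beyond the scatter), removed the phenyl ring itself and concerned the tetraphosphate pair. No measurement at hand accounts for the shift with the shorter chain.

The compounds shown leave open how the triphosphate compounds would respond to methoxy, the group carried by compound 2, and how an ethoxy chain or a longer chain ending in phenyl would read at this position. They also leave open whether an amine or a carboxylic acid on the phenyl ring would move the number in either direction.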